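Compound 3 to compound 4: working notes on the series

This account rests on a few compounds, and the source may have more. Where it says the series, first, only, none or still open, it means among the compounds named here.

Values in an ADME assay on RAW264.7 cells (Mus musculus) for cytotoxicity, read by MTT assay, with a stated time of 24 h; a higher number here means that more compound is tolerated, a lower number that less compound is tolerated:
- compound 1 `CC/C=C\C[C@H]1C(=O)C=C[C@H]1CC(=O)OCc1ccccc1`: 31 uM
- compound 2 `CC/C=C\C[C@H]1C(=O)C=C[C@H]1CC(=O)Oc1ccc(O)cc1`: 49 uM
- compound 3 `CC/C=C\C[C@H]1C(=O)C=C[C@H]1CC(=O)OCCOCCO`: 166 uM

Compound 3 stands highest of the three at 166 uM. Compound 4 `CC/C=C\C[C@H]1C(=O)C=C[C@H]1CC(=O)OC(C)C` has isopropyl in place of 2-(2-hydroxyethoxy)ethyl on an oxygen next to a carbonyl group. Going by the values given here, two measured steps bear on this change, both modest and beyond the scatter: a 5.4-fold higher number from compound 1 to compound 3 (0.73 log units; beyond the scatter) and a 3.4-fold higher number from compound 2 to compound 3 (0.53 log units; beyond the scatter). Both end at compound 3 and start from a group other than 2-(2-hydroxyethoxy)ethyl. The step of a 1.6-fold higher number from compound 1 to compound 2 (0.20 log units; within the scatter) stays within the scatter. Among the compounds with values here, no isopropyl compound has been measured, so the size remains uncertain. In this assay, a modest fall is expected: a 3.0-fold lower number from compound 3 to compound 4 (0.48 log units; beyond the scatter). Compound 4 is estimated at 55 uM, with an expected range of 22 uM to 130 uM.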

Compound 4, half-maximal toxic concentration: 58 uM
For compound 4 the middle estimate is 1.1-fold (0.02 log units) below the measured one; the range from low to high includes it.
By their numbers in this assay, from the lowest: compounds 1, 2 and 4 (each within the scatter of the next); then compound 3.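

In this assay, the change to isopropyl gives a 2.9-fold lower number from compound 3 to compound 4 (0.46 log units; beyond the scatter), while a 1.2-fold higher number from compound 2 to compound 4 (0.07 log units; within the scatter) and a 1.9-fold higher number from compound 1 to compound 4 (0.27 log units; within the scatter) both stay within the scatter. Having no ring is therefore not enough on its own to match compound 3, since compound 4 also has no ring but stays within the scatter of compound 1 and compound 2. No measurement bearing on the reason for this result is available.

Going by these compounds, it remains open which part of 2-(2-hydroxyethoxy)ethyl goes with the higher number. A 2-hydroxyethyl, a 2-methoxyethyl or a longer chain of repeating ethoxy units on this oxygen would address that.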